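The compounds below may be only part of what the source reports. "The series", "measured", "known", "first", "only" and "open" are said of these compounds alone.

Measured so far in a physicochemical assay for solubility; a higher number here means a more soluble compound, a lower number a less soluble compound
Compound 1 `O=C(c1ccc(Cl)nc1)N1CCC(NS(=O)(=O)c2cc(S(=O)(=O)c3ccccc3)ccc2C(F)(F)F)CC1` gives 25000 nM
Compound 2 `N#Cc1cccc(S(=O)(=O)N2CCC(NS(=O)(=O)c3cc(S(=O)(=O)c4ccccc4)ccc3C(F)(F)F)CC2)c1` gives 6300 nM
Compound 3 `O=C(O)CCCC(=O)N1CCC(NS(=O)(=O)c2cc(S(=O)(=O)c3ccccc3)ccc2C(F)(F)F)CC1` is not yet measured

Compound 2 at 6300 nM holds the lower of the two numbers, beyond the scatter from compound 1. Compound 3 carries (3-carboxypropyl)carbonyl in place of (3-cyanophenyl)sulfonyl on an amine nitrogen in a ring and the rest stays the same. Going by the values given here, one measured step bears on this: a 4.0-fold lower number from compound 1 to compound 2 (0.60 log units; beyond the scatter) when (3-cyanophenyl)sulfonyl entered at that nitrogen. Compound 3 removes that group and restores a carbonyl there, so a rise of similar size is expected in this assay on this single step. The expected change is a 4.8-fold higher number from compound 2 to compound 3 (0.68 log units; beyond the scatter) as estimated here. The estimate for compound 3 is 30000 nM with an expected range from 10000 nM to 100000 nM overall.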

Compound 3, solubility: 50000 nM
For compound 3 the middle estimate is 1.7-fold (0.22 log units) below the measured one; the range from low to high includes it.
By their numbers in this assay, from the lowest: compound 2; then compounds 1 and 3 (each within the scatter of the next).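

In this assay, the amine nitrogen in the ring accepts very different groups: (3-carboxypropyl)carbonyl in place of (3-cyanophenyl)sulfonyl gives a 7.9-fold higher number from compound 2 to compound 3 (0.90 log units; beyond the scatter) and reverses the earlier fall. With 3-carboxypropyl in place of 6-chloropyridin-3-yl on the carbonyl carbon, the data show a 2.0-fold higher number from compound 1 to compound 3 (0.30 log units; within the scatter) and so cannot separate these two carbonyl compounds. Nothing measured here explains these numbers.

Open, on these data alone, is whether the sulfonyl link or the group it carries sets the low number of compound 2. A sulfonyl bearing a 3-carboxypropyl chain, or a carbonyl bearing a chain that ends in an amine, would help to separate the two.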